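Saturated ring size at the chain amine: compound 3 to compound 4

This account rests on a few compounds, and the source may have more. Where it says the series, first, only, none or still open, it means among the compounds named here.

Compound 3 `COc1cc2c(Nc3nc4ccc(C(=O)Nc5c(C)cccc5Cl)cc4s3)ncnc2cc1OCCCN1CCCCC1` gives 13800 nM in a functional assay on NCI-H661 cells (Homo sapiens) for cytotoxicity, read by WST assay, with a stated time of 72 h (on this read-out lower numbers stand for stronger inhibition and higher numbers for weaker inhibition), the higher of the two numbers in hand, though its gap to compound 1 `COc1cc2c(Nc3nc4ccc(C(=O)Nc5c(C)cccc5Cl)cc4s3)ncnc2cc1OCCCN1CCC(C)CC1`, which gives 7900 nM, is within the scatter. Compound 2 `COc1cc2c(Nc3nc4ccc(C(=O)Nc5c(C)cccc5C)cc4s3)ncnc2cc1OCCCN1CCCC1` returns only a limit of the assay, > 100000 nM, as noted by the limit of > 100000 nM in this assay, at which 1 of the 3 values shown sits. For the measured compounds named here, the single measured step, a 1.7-fold higher number from compound 1 to compound 3 (0.24 log units; within the scatter), stays within the scatter. Compound 4 `COc1cc2c(Nc3nc4ccc(C(=O)Nc5c(C)cccc5Cl)cc4s3)ncnc2cc1OCCCN1CCCC1` differs from compound 3 by pyrrolidin-1-yl in place of piperidin-1-yl on a saturated chain carbon, three bonds along the chain from an oxygen on an aromatic ring. Going by the values given here, no measured pair covers this change; the one step seen at the saturated ring was small, so a step no larger than the scatter is expected, if anything toward a higher number. For compound 4 the estimated value is 18000 nM, with a range from 6000 nM to 60000 nM, which means an expected step of a 1.3-fold higher number from compound 3 to compound 4 (0.12 log units; within the scatter).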

Compound 4, half-maximal inhibitory concentration: 45500 nM
Compound 4: middle estimate off by 2.5-fold (0.40 log units), on the low side; low and high end bracket the measured number.
By their numbers in this assay, from the lowest: compounds 1 and 3 (each within the scatter of the next); then compound 4. At a limit, above all of these: compound 2.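

Ring size at the chain amine registers in this assay where the ring methyl did not: shrinking the ring gives a 3.3-fold higher number from compound 3 to compound 4 (0.52 log units; beyond the scatter) and a 5.8-fold higher number from compound 1 to compound 4 (0.76 log units; beyond the scatter), against only a 1.7-fold higher number from compound 1 to compound 3 (0.24 log units; within the scatter) for removing the methyl. With pyrrolidin-1-yl kept, chloro in place of methyl on an aromatic carbon gives an at least 2.1-fold lower number from compound 2 to compound 4 (0.34 log units; beyond the scatter). That step rests on compound 2, whose value is a limit: the limit of > 100000 nM in this assay, at which 1 of the 4 values shown sits.

Open, as far as these compounds go, is whether azepan-1-yl or morpholin-4-yl at the chain end would sit with the piperidin-1-yl or the pyrrolidin-1-yl compounds. Also open, from the compounds shown here alone, is how a shorter or longer chain would shift these values.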